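Methyl for 2-aminophenyl on the amide of compound 2

A few compounds are considered here, and "the series" means these few. Any claim that something is new, unique, unknown or untested is made for them only; others in the source may bear on it.

Measured in a functional assay on HCT-116 cells (Homo sapiens) for antiproliferative activity, read by sulforhodamine B assay, with a stated time of 72 h; on this read-out lower numbers stand for stronger inhibition and higher numbers for weaker inhibition:
compound 1 `Cn1cc(-c2ccc(=O)n(CCOc3ccnc4cc(OCCCC(=O)NO)ccc34)n2)cn1`: > 10000 nM (a limit)
compound 2 `Cn1cc(-c2ccc(=O)n(CCOc3ccnc4cc(OCCCCCC(=O)Nc5ccccc5N)ccc34)n2)cn1`: 7000 nM
compound 3 `Cn1cc(-c2ccc(=O)n(CCOc3ccnc4cc(OCCCCCS)ccc34)n2)cn1`: > 10000 nM (a limit)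

Among the measured compounds shown here, compound 2 holds the only actual number in the set. The other two values are limits: the limit of > 10000 nM in this assay, at which 2 of the 3 values shown sit.

Compound 4 `CNC(=O)CCCCCOc1ccc2c(OCCn3nc(-c4cnn(C)c4)ccc3=O)ccnc2c1` differs from compound 2 as follows: methyl in place of 2-aminophenyl on an amide-type nitrogen. This places methyl in place of 2-aminophenyl on an amide-type nitrogen.

For the measured compounds named here, two measured steps bear on this change, since each involves losing the (2-aminophenyl)carbamoyl group: an at least 1.4-fold lower number from compound 1 to compound 2 (0.15 log units; that floor lies within the scatter), and an at least 1.4-fold higher number from compound 2 to compound 3 (0.15 log units; that floor lies within the scatter). Both give only floors, so a rise is expected, possibly to a limit. The expected step is a 1.7-fold higher number from compound 2 to compound 4 (0.23 log units; within the scatter). The estimate for compound 4 is 12000 nM, with an expected range of 5000 nM to 30000 nM.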

Compound 4, half-maximal inhibitory concentration: > 10000 nM
Compound 4: a limit, no number (the forecaster's own chance of this, stated with the estimate: 70%); the middle value lies beyond the limit too.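

Compound 4 gives > 10000 nM in this assay, which is a limit. Methyl in place of 2-aminophenyl on the amide-type nitrogen gives an at least 1.4-fold higher number from compound 2 to compound 4 (0.15 log units; that floor lies within the scatter), so no gain appears with methyl, but a real loss is not established either. Compound 2 remains the only compound with an actual number, and the set now gathers at a single limit: the limit of > 10000 nM in this assay, at which 3 of the 4 values shown sit.

The steps from compound 1 and compound 3 to compound 4 cannot be read, as both ends of each are limits. Going by these compounds, whether a plain phenyl or a 2-hydroxyphenyl on the amide-type nitrogen would keep a number like that of compound 2 remains open.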